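Swapping a Hydroxyphenoxy Group for a Dichlorophenylsulfanyl Group

The source may report more compounds than this note shows. Statements on the series, on what has been measured and on what is new or still open speak of the compounds shown alone.

Measured compounds:
- compound 1, `CC(C)C[C@H](N)c1ccccc1N1CCN(C(=O)[C@H](C)Cc2ccc(Cl)cc2F)CC1`: 67 nM
- compound 2, `CC(C)C[C@H](N)c1cc(Cl)ccc1N1CCN(C(=O)C(C)Cc2ccc(Cl)cc2)CC1`: 67 nM
- compound 3, `CC(C)C[C@H](N)c1cc(C(F)(F)F)ccc1N1CCN(C(=O)COc2ccc(O)cc2)CC1`: 4600 nM

In an assay on HEK293 cells for displacement of a labelled ligand from Melanocortin receptor 4 (Homo sapiens) (a higher number here means a weaker inhibitor, a lower number a stronger inhibitor), compound 3 gives the highest number of the three, and its gap to compound 1 and to compound 2 lies beyond the scatter of repeated measurements, so compound 3 is the weakest inhibitor of this set. Compound 1 and compound 2 sit close together at the stronger end.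

Compound 4, `CC(C)C[C@H](N)c1cc(C(F)(F)F)ccc1N1CCN(C(=O)CSc2ccc(Cl)cc2Cl)CC1`, has not yet been measured in this assay. It differs from compound 3 in one place: (2,4-dichlorophenyl)sulfanyl in place of 4-hydroxyphenoxy on a saturated chain carbon bound to a carbonyl carbon. The part that leaves carries a hydrogen-bond donor and two acceptors; the part that enters carries two chlorines and a sulfur with no donor.

Among the measured compounds shown here, no pair of measured compounds shows this exact change, so the expected size of the step rests on where compound 3 stands against compound 1 and compound 2. A step toward stronger inhibition, larger than the scatter, is expected from compound 3 to compound 4, an 18-fold lower number from compound 3 to compound 4 (1.26 log units; beyond the scatter). Compound 4 is estimated at 250 nM, with a plausible range from 50 nM to 1200 nM.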

Compound 4, inhibition constant: 1500 nM
Compound 4: the middle estimate sits 6.0-fold (0.78 log units) below what was measured, outside the stated range (above it).
By their numbers in this assay, from the lowest: compounds 1 and 2 (each within the scatter of the next); then compound 4; then compound 3.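

In this assay, among the compounds shown here, putting (2,4-dichlorophenyl)sulfanyl in place of 4-hydroxyphenoxy gives a 3.1-fold lower number from compound 3 to compound 4 (0.49 log units; beyond the scatter), the first step in this set that can be read across a single change. So the number does respond to what sits on this saturated chain carbon bound to a carbonyl carbon, and here the loss of the hydrogen-bond donor comes with stronger inhibition, though the step is only modest. Nothing measured here accounts for the size or direction of this step.

The change alters several things at once, the sulfur, the two chlorines and the missing hydroxyl, and the compounds shown do not separate them. A 2,4-dichlorophenoxy group would keep the chlorines with oxygen in place of sulfur, and a plain phenylsulfanyl group would keep the sulfur without the chlorines.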